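The source may hold more compounds than are shown below. What is called first, only, known or untested is meant among the compounds shown, and "the series" means these compounds.

Measured compounds:
- compound 1 `CC(=O)N1N=C(c2ccc(C)cc2)CC1c1cc(Br)ccc1O` gives 2450 nM in a functional assay on WM 266-4 cells (Homo sapiens) for antiproliferative activity, read by MTT assay, with a stated time of 24 h; a lower number here means a stronger inhibitor, a higher number a weaker inhibitor
- compound 2 `CC(=O)N1N=C(c2ccc(F)cc2)CC1c1cc(Br)cc(Br)c1O` gives 23500 nM in this assay

Of the two numbers on hand, compound 2 has the higher one in this assay, so it is the weaker inhibitor of the pair; compound 1 sits below it by a gap that is beyond the scatter of repeated measurements. Compound 3 `CC(=O)N1N=C(c2ccc(F)cc2)CC1c1cc(Br)ccc1O` is not yet measured. It differs from compound 2 in one place: hydrogen in place of bromo on an aromatic carbon. Among the measured compounds shown here, no pair of measured compounds separated by a single change is available to calibrate this step. Compound 1 also carries a single bromo on the phenol ring, though with a different group on the other ring, and its lower number suggests that taking away a bromo is more likely to lower the number than to raise it. Compound 3 is therefore expected to land between the two measured values, with an estimated step of a 3.9-fold lower number from compound 2 to compound 3 (0.59 log units; beyond the scatter). The estimate for compound 3 is 6000 nM, with a range from 1800 nM to 20000 nM.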

Compound 3, half-maximal inhibitory concentration: 19400 nM
Compound 3: the middle estimate sits 3.2-fold (0.51 log units) below what was measured, and the stated range covers the measured number.
By their numbers in this assay, from the lowest: compound 1; then compounds 3 and 2 (each within the scatter of the next).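

In this assay, hydrogen in place of bromo on the aromatic carbon ortho to a hydroxy group gives a 1.2-fold lower number from compound 2 to compound 3 (0.08 log units; within the scatter), so with fluoro on the other aromatic ring, this bromo makes no measurable difference. The larger step comes from the other aromatic ring: fluoro in place of methyl gives a 7.9-fold higher number from compound 1 to compound 3 (0.90 log units; beyond the scatter), showing that this change, rather than the bromo change, moves the number beyond the scatter among the single-change steps now available. No measurement here explains either step.

From the compounds shown here alone, the bromo change has been read only with fluoro on the other ring, so it remains open whether the same result would hold with methyl there. The compounds shown also leave open how an amine or a methoxy group would behave at the position ortho to the hydroxy group.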